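Succinimide-propanamide piperazines in the maximal electroshock model

This account rests on a few compounds, and the source may have more. Where it says the series, first, only, none or still open, it means among the compounds named here.

Measured so far:
compound 1 `COc1cccc(N2CCN(C(=O)C(C)N3C(=O)CCC3=O)CC2)c1`: 0%
compound 2 `CCC(C(=O)N1CCN(c2cccc(OC)c2)CC1)N1C(=O)CCC1=O`: 0%
compound 3 `CC(C(=O)N1CCN(c2ccc(C(F)(F)F)cc2)CC1)N1C(=O)CCC1=O`: 0%

In a functional assay on the whole organism (strain Swiss) with Mus musculus as the target, in the maximal electroshock model, with a stated time of 2 h, at a dose of 300 mg/kg by the intraperitoneal route (on this read-out lower numbers stand for a weaker effect and higher numbers for a stronger effect at the one dose given), compound 1 gives 0%, compound 2 gives 0% and compound 3 gives 0%. Compound 2 carries the change methyl in place of hydrogen on a saturated chain carbon, two bonds along the chain from an amide-type nitrogen in a ring and a carbonyl carbon relative to compound 1, and the step of no change at the digits printed from compound 1 to compound 2 (within the scatter) shows no effect. The difference between the core of compound 1 and the core of compound 3 is not broken down here. Compound 4 `CCC(C(=O)N1CCN(c2ccc(C(F)(F)F)cc2)CC1)N1C(=O)CCC1=O` has not yet been tested; it differs from compound 3 by methyl in place of hydrogen on a saturated chain carbon, two bonds along the chain from an amide-type nitrogen in a ring and a carbonyl carbon, the same change as made from compound 1 to compound 2, at the same place. Among the compounds with values here, since that change left compound 2 level with compound 1, the step expected in this assay is no change at the digits printed from compound 3 to compound 4 (within the scatter), resting only on the one earlier instance. Compound 4 is therefore estimated at 0%, with a range from 0% to 10%.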

Compound 4, a percentage reported as activity, at one dose (the size of the read-out at that dose, not a potency): 0%
For compound 4 middle estimate and measured number coincide at the digits printed; the range from low to high includes it.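

In this assay methyl in place of hydrogen on the saturated chain carbon gives no change at the digits printed from compound 3 to compound 4 (within the scatter), and the change reads alike on both cores: the same change on two cores in this assay, no change at the digits printed (within the scatter) from compound 1 to compound 2 and no change at the digits printed (within the scatter) from compound 3 to compound 4, 0 percentage points apart, within the scatter of two such steps

Within the data shown here, compound 4 stands at 0%, level with the other three compounds, so the agreement shows only that the change leaves both cores at that same reading at this one dose. Among these compounds, it does not show that the change is generally without effect, since no compound here gives a higher reading against which an effect could appear, and two cores are a narrow base.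

Open, on these data alone, is whether a longer chain at that carbon, such as propyl, or a chlorine or nitrile in place of trifluoromethyl gives any reading in this assay. Equally open, as far as these compounds go, is whether the methyl change would carry over on a core with a measurable reading.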